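Unbound share after losing the dimethylsulfamoyl group

The source may hold more compounds than are shown below. What is called first, only, known or untested is meant among the compounds shown, and "the series" means these compounds.

Measured in an ADME assay on a cell-free system (plasma, Homo sapiens); a higher number here means a larger unbound share of the compound, a lower number a smaller unbound share:
Compound 1 `CC(C)S(=O)(=O)c1ccc(Cl)c(C#Cc2cc(Cl)ccc2OCC(=O)O)c1`: "not determined" (no result reported)
Compound 2 `CN(C)S(=O)(=O)c1cncc(C#Cc2cc(Cl)ccc2OCC(=O)O)c1`: 0.033

Among the compounds with values here, compound 2 holds the only number so far, so it cannot be ranked, and compound 1 has no reported result. Compound 3 `O=C(O)COc1ccc(Cl)cc1C#Cc1cccnc1` follows from compound 2 through (hydrogen in place of dimethylsulfamoyl on an aromatic carbon), hydrogen in place of dimethylsulfamoyl on an aromatic carbon. Within the data shown here, no measured pair shows what this change does in this assay. Among the measured compounds shown here, the only anchor is compound 2 at 0.033, so a step within the scatter is expected, with no firm direction. The expected change is a 1.2-fold higher number from compound 2 to compound 3 (0.08 log units; within the scatter). For compound 3 the estimate is 0.04, with an expected range of 0.015 to 0.1.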

Compound 3, unbound fraction: 0.029
The estimate for compound 3 lay 1.4-fold (0.14 log units) above the measured number; low and high end bracket the measured number.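

Hydrogen in place of dimethylsulfamoyl on this aromatic carbon gives a 1.1-fold lower number from compound 2 to compound 3 (0.06 log units; within the scatter) in this assay, the only reading of this change in the series. At this position, then, the dimethylsulfamoyl group can be removed without a step beyond the scatter in the unbound share. No data bearing on the reason accompany this result.

On these data alone, whether an amine or a carboxylic acid on this same aromatic carbon would shift the unbound share remains open. Also open, as far as these compounds go, is whether this replacement gives a similar step on a different core.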